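The compounds below may be only part of what the source reports. "The series", "measured", "known", "first", "only" and "open" are said of these compounds alone.

Working notes on the series. In a functional assay on HeLa cells (Homo sapiens) for antiproliferative activity, read by MTT assay, with a stated time of 72 h (on this read-out lower numbers stand for stronger inhibition and higher numbers for weaker inhibition), compound 1 `COc1cc(C(=O)c2sc3ccccc3c2-c2ccccc2)cc(OC)c1OC` gives 1900 nM and compound 2 `CCOc1ccc(-c2c(C(=O)c3cc(OC)c(OC)c(OC)c3)sc3ccccc23)cc1` gives 3000 nM. Among the compounds with values here, these are the only two measured points, and they cannot be ranked: the single measured step is a 1.6-fold higher number from compound 1 to compound 2 (0.20 log units; within the scatter), for ethoxy in place of hydrogen on an aromatic carbon. Within the data shown here, compound 2 therefore stands level with its one neighbour.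

Compound 3 `COc1cc(C(=O)c2sc3ccccc3c2Nc2ccccc2)cc(OC)c1OC` is next. The change from compound 2 is anilino in place of 4-ethoxyphenyl on an aromatic carbon: anilino in place of 4-ethoxyphenyl, on an aromatic carbon of a five-membered aromatic ring with 1 sulfur.

The measured step bears on this only in part. Among the measured compounds shown here, it covers the ethoxy, which leaves with the 4-ethoxyphenyl, but no measured compound carries anilino. On this slim evidence, no step beyond the scatter is expected in this assay, and no direction can be firmly assigned. The range is kept wide for the same reason.

Compound 3 is expected at 2000 nM, with an estimated range of 400 nM to 10000 nM. The estimate corresponds to an expected 1.5-fold lower number from compound 2 to compound 3 (0.18 log units; within the scatter).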

Compound 3, half-maximal inhibitory concentration: 2700 nM
Compound 3: middle estimate off by 1.4-fold (0.13 log units), on the low side; low and high end bracket the measured number.
By their numbers in this assay, from the lowest: compounds 1, 3 and 2 (each within the scatter of the next).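

In this assay, anilino in place of 4-ethoxyphenyl gives a 1.1-fold lower number from compound 2 to compound 3 (0.05 log units; within the scatter) and anilino in place of phenyl gives a 1.4-fold higher number from compound 1 to compound 3 (0.15 log units; within the scatter), so neither exchange at this position moves the number beyond the scatter. Within the data shown here, this is the first comparison at this aromatic carbon, two ring bonds from the ring sulfur, and it shows that the read-out does not separate a directly attached aromatic ring from anilino, which brings a nitrogen and 1 hydrogen-bond donor while still presenting a six-membered aromatic ring of carbon only. Nothing available offers an explanation for this level outcome.

As far as these compounds go, all three compounds carry a six-membered aromatic ring of carbon only at this position, so it remains open whether a morpholine, a carboxylic acid or a longer alkyl chain there would give a step beyond the scatter. Also open, from the compounds shown here alone, is whether ethoxy on the anilino ring would behave as it does on the phenyl ring, and whether any change at this position can bring the number clearly away from the level shared by these three compounds.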